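The compounds below may be only part of what the source reports. "The series", "measured", "known", "first", "only" and "open" are said of these compounds alone.

Measured compounds:
Compound 1, `COc1ccc(Oc2ccc3cc(NC(=O)c4ccc(OC(C)=O)c(CC=C(C)C)c4)c(=O)oc3c2C)cc1`: in a functional assay on SK-BR-3 cells (Homo sapiens) for antiproliferative activity (on this read-out lower numbers stand for stronger inhibition and higher numbers for weaker inhibition), compound 1 gives 19500 nM.
Compound 2, `COc1ccc(Oc2ccc3cc(NC(=O)c4ccc(O)c(CC=C(C)C)c4)c(=O)oc3c2C)cc1`: in this assay compound 2 gives 42700 nM.
Compound 3, `COc1ccc(Nc2ccc3cc(NC(=O)c4ccc(OC)c(-c5cccc(OC)c5)c4)c(=O)oc3c2C)cc1`: in this assay compound 3 reaches only the limit > 100000 nM, which is a limit of the assay and not a number.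

Compound 2 holds the highest of the two numbers reported, with compound 1 nearest; the step of a 2.2-fold higher number from compound 1 to compound 2 (0.34 log units; beyond the scatter) is modest but beyond the scatter. For the measured compounds named here, the one remaining value is a limit (the limit of > 100000 nM in this assay, at which 1 of the 3 values shown sits).

Compound 4, `COc1cccc(Cc2ccc3cc(NC(=O)c4ccc(O)c(CC=C(C)C)c4)c(=O)oc3c2C)c1`, has not yet been measured. It differs from compound 2 in one place: 3-methoxybenzyl in place of 4-methoxyphenoxy on an aromatic carbon. Going by the values given here, none of the measured steps changes this part of the molecule, so no step bears directly on it. Compound 3 carries a different group at this position, along with other changes, and gives only a limit, which shows that altering this region does not lead to a strong inhibitor among these compounds. Compound 4 is therefore expected to stay close to compound 2, with the step of a 1.2-fold higher number from compound 2 to compound 4 (0.07 log units; within the scatter) estimated to lie within the scatter. The estimate for compound 4 in this assay is 50000 nM, within a range from 15000 nM to 150000 nM.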

Compound 4, half-maximal inhibitory concentration: 14800 nM
Compound 4: middle estimate off by 3.4-fold (0.53 log units), on the high side; the measured number lies below the stated range.
By their numbers in this assay, from the lowest: compounds 4 and 1 (each within the scatter of the next); then compound 2. At a limit, above all of these: compound 3.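

For the compounds shown here, no earlier step touched this aromatic carbon, ortho to a methyl group, and a single change there, 3-methoxybenzyl in place of 4-methoxyphenoxy, tested in this assay gives a 2.9-fold lower number from compound 2 to compound 4 (0.46 log units; beyond the scatter). So the position does respond to a change in its substituent, but this swap alters two things at once: the oxygen link to the ring becomes a carbon link, and the methoxy group moves to a different place on that ring. Nothing measured here gives a reason for the shift.

Which of those two alterations matters stays open, and the 4-methoxybenzyl and 3-methoxyphenoxy groups would pull them apart. How a plain benzyl group, with no methoxy at all, would behave at this position is also unknown.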